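The source may hold more compounds than are shown below. What is called first, only, known or untested is meant among the compounds shown, and "the series" means these compounds.

Measured compounds:
Compound 1, `O=C(Nc1ccccc1OC(F)(F)F)Nc1n[nH]c2ccccc12`: 51700 nM
Compound 2, `Nc1nn(C(=O)Nc2ccc(Cc3ccccc3)cc2)c2ccccc12`: 1020 nM

Both compounds were tested in a functional assay on DU-145 cells (Homo sapiens) for inhibition, read by sulforhodamine B assay, with a stated time of 48 h; on this read-out higher numbers stand for weaker inhibition of growth and lower numbers for stronger inhibition of growth. Compound 1 gives 51700 nM and compound 2 gives 1020 nM, so compound 2 stands with the lower of the two numbers, and its gap to compound 1 lies beyond the usual scatter. For the measured compounds named here, the two compounds differ from each other in more than one place, so their pair shows only the two values and no single structural step.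

Compound 3, `CCCCOc1ccc(NC(=O)n2nc(N)c3ccccc32)cc1`, has not yet been measured. It differs from compound 2 in one place: butoxy in place of benzyl on an aromatic carbon. In short, butoxy takes the place of benzyl on an aromatic carbon, para to a large group.

Going by the values given here, no measured pair shows this kind of exchange, so there is no recorded step to lean on. Because compound 2 already gives 1020 nM, the expectation is a modest step toward a higher number, from compound 2 to compound 3 of a 2.0-fold higher number from compound 2 to compound 3 (0.29 log units; within the scatter), close to the edge of the scatter. Compound 3 is therefore expected to give about 2000 nM, with a likely range from 600 nM to 7000 nM.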

Compound 3, concentration for 50% growth inhibition: 25000 nM
For compound 3 the middle estimate is 13-fold (1.10 log units) below the measured one; the measured number lies above the stated range.
By their numbers in this assay, from the lowest: compound 2; then compound 3; then compound 1.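

In this assay, for the compounds shown here, the exchange of benzyl for butoxy gives a 25-fold higher number from compound 2 to compound 3 (1.39 log units; beyond the scatter) and is the first direct view of this position, an aromatic carbon para to a large group. The group held there clearly matters, as growth inhibition becomes much weaker when the benzyl group, with its six-membered aromatic ring of carbon only, gives way to butoxy, which has no ring and brings in an oxygen. The change alters several features at once, and no separate measurement on these compounds accounts for the size of the step.

Whether the loss follows the missing ring, the added oxygen or the shape of the chain stays open, since the compounds shown include neither a benzyloxy group, which would pair the ring with an oxygen, nor a pentyl chain, which would offer an open chain without one. Also open, as far as these compounds go, is how a shorter or longer chain, such as methoxy or hexyloxy, would read in this assay at this position.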